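The compounds below may be only part of what the source reports. "The series", "measured", "known", "first", "only" and "open" are said of these compounds alone.

Measured in an assay on a protein complex for inhibition of CDK8/Cyclin C (Homo sapiens), with a stated time of 1 h, tested at 10 uM; on this read-out lower numbers stand for less inhibition and higher numbers for more inhibition at the one concentration tested (going by the name of the read-out):

Compound 1, `CNC(=O)/C=C/c1ccncc1-c1ccc2ccccc2c1`, gives 101%.
Compound 2, `CNC(=O)/C=C/c1ccncc1-c1ccc2cc[nH]c2c1`, gives 103%.
Compound 3, `CCOC(=O)/C=C/c1ccncc1-c1ccc2ccccc2c1`, gives 102%.

All three compounds share a propenyl chain on a pyridine ring carrying a bicyclic aromatic group, and all three give readings close to one another in this assay. Compound 1 and compound 3 are related by a single change, (ethoxy in place of methylamino on a carbonyl carbon), and the step between them in this assay is a number 1 percentage points higher from compound 1 to compound 3 (within the scatter), so the two readings cannot be told apart at this concentration. Compound 2 carries a different bicyclic core than compound 1; the difference between the two cores is not broken down here, and the readings of compound 1 and compound 2 in this assay are also within the scatter of each other.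

Compound 4, `CCOC(=O)/C=C/c1ccncc1-c1ccc2cc[nH]c2c1`, has not yet been measured. Within the data shown here, it differs from compound 2 by ethoxy in place of methylamino on a carbonyl carbon, which is the same change as the one from compound 1 to compound 3, made at the same place. Since that change produced a step of a number 1 percentage points higher from compound 1 to compound 3 (within the scatter) on the core of compound 1, and since compound 2 already reads 103%, a step of about a number 2 percentage points lower from compound 2 to compound 4 (within the scatter) is expected from compound 2 to compound 4 in this assay. Compound 4 is therefore estimated to give 101% in this assay, with a likely range from 92% to 108%.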

Compound 4, a percentage reported as inhibition, at one concentration (the size of the read-out at that concentration, not a potency): 104%
For compound 4 the middle estimate is 3 percentage points below the measured one; measured number inside the range.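

In this assay, putting ethoxy in place of methylamino on a carbonyl carbon on the second core gives a step that reads a number 1 percentage points higher from compound 2 to compound 4 (within the scatter), so compound 4 cannot be told apart from compound 2 at this concentration. Set beside the same change on the core of compound 1, the step carries over from one core to the other without a readable difference: the same change on two cores in this assay, a number 1 percentage points higher (within the scatter) from compound 1 to compound 3 and a number 1 percentage points higher (within the scatter) from compound 2 to compound 4, 0 percentage points apart, within the scatter of two such steps. Among these compounds, this shows only that the change leaves no mark that can be read on either of these two cores at the one concentration tested; it does not show that methylamino and ethoxy are equivalent in potency, since a single-concentration reading is not a potency and all four readings lie close together, leaving no room to see whether the two cores respond differently.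

The compounds shown leave open how a carboxylic acid, a dimethylamino group or a longer alkoxy chain on the same carbonyl carbon would read, and whether the change would behave alike on a core other than these two. They also leave open how the four compounds would separate at concentrations lower than the one tested.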